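The source may report more compounds than this note shows. Statements on the series, on what has been measured and on what is new or still open speak of the compounds shown alone.

Within the data shown here, in a functional assay (plasma) for inhibition, with Oryctolagus cuniculus as the target (a higher number here means a weaker inhibitor, a lower number a stronger inhibitor), compound 2 `O=C(O)CCC/C=C\C[C@H]1[C@@H]2CCC(C2)[C@@H]1NS(=O)(=O)c1ccc([N+](=O)[O-])cc1` gives 1400 nM, the only single number among the three compounds measured so far. Compound 1 `CC1(C)[C@H]2C[C@H](NC(=O)[C@H](O)C3CCCC3)[C@@H](C/C=C\CCCC(=O)O)[C@@H]1C2` reaches only a limit of the assay, > 800000 nM. Compound 3 `O=C(O)CCC/C=C\C[C@H]1[C@@H]2CCC(C2)[C@@H]1NS(=O)(=O)c1ccccc1` appears with several entries, 1000 nM; 7400 nM; 600 nM (3 entries), and the spread of the several entries of compound 3 in this assay, 1000 nM; 7400 nM; 600 nM (3 entries) yields no single settled number for it. Compound 4 `COc1ccc(S(=O)(=O)N[C@H]2C3CC[C@H](C3)[C@@H]2C/C=C\CCCC(=O)O)cc1` has not yet been measured in this assay. It differs from compound 2 by methoxy in place of nitro on an aromatic carbon. Among the measured compounds shown here, no step between measured compounds is available with which to weigh this change; the values of compound 2 and compound 3 show only that the compound carrying the nitro group and the one without it land in the same region of this assay. A small step is therefore expected, a 1.4-fold higher number from compound 2 to compound 4 (0.15 log units; within the scatter), a slight weakening that may well stay within the usual scatter. Compound 4 is accordingly estimated at 2000 nM, within a range from 600 nM to 7000 nM.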

Compound 4, half-maximal inhibitory concentration: 1700 nM
The estimate for compound 4 lay 1.2-fold (0.07 log units) above the measured number, and the stated range covers the measured number.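

In this assay, among these compounds, the exchange of nitro for methoxy on this aromatic carbon gives the first step that can be read at this place: a 1.2-fold higher number from compound 2 to compound 4 (0.08 log units; within the scatter). At this place, para to a large group, going from 4-nitrophenyl to 4-methoxyphenyl therefore leaves compound 2 and compound 4 within the scatter of each other. Compound 3, which carries neither group, gives no firm reference for either of them, because its entries do not settle on one number: the several entries of compound 3 in this assay, 1000 nM; 7400 nM; 600 nM (3 entries).

Going by these compounds, it remains open whether an amine or a carboxylic acid at this same place would also stay in this region of this assay. Also open, on these data alone, is whether methoxy on another carbon of the ring would give an equally small step.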